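A few compounds are considered here, and "the series" means these few. Any claim that something is new, unique, unknown or untested is made for them only; others in the source may bear on it.

Compound 1 `N#Cc1ccc(Nc2nccc(Oc3ccc(-c4ccc(C#N)cc4)c(F)c3)n2)cc1` was examined in a functional assay on MT4 cells (Homo sapiens) for cytotoxicity, read by MTT assay, with a stated time of 5 days; a higher number here means that more compound is tolerated, a lower number that less compound is tolerated. In this assay compound 1 gives > 307000 nM, which is a limit of the assay and not a number. Compound 2 `N#Cc1ccc(Nc2nccc(Oc3ccc(-c4ccc(C#N)cc4)cc3C(F)(F)F)n2)cc1` was examined in this assay as well; compound 2 gives > 273000 nM, again a limit rather than a number. Compound 1 thus stands at the ceiling of what the measurements shown can resolve, a situation summarized by the limit of > 307000 nM in this assay, at which 1 of the 2 values shown sits, together with the limit of > 273000 nM in this assay, at which 1 of the 2 values shown sits. Compound 3 `N#Cc1ccc(Nc2nccc(Oc3ccc(-c4ccc(C#N)cc4)c(Cl)c3)n2)cc1` differs from compound 1 by chloro in place of fluoro on an aromatic carbon. Going by the values given here, no step between two measured compounds is available to calibrate this change in this assay, and both measured values are limits. The expectation for compound 3 is therefore a step of an at least 1.2-fold lower number from compound 1 to compound 3 (0.08 log units; that floor lies within the scatter), that is, none beyond the scatter, with the result most likely reported as a limit once more. For compound 3 the estimated value is 250000 nM, with a range from 80000 nM to 400000 nM.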

Compound 3, half-maximal cytotoxic concentration: 31100 nM
For compound 3 the middle estimate is 8.0-fold (0.91 log units) above the measured one, outside the stated range (below it).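

In this assay, chloro in place of fluoro on this aromatic carbon, ortho to a 4-cyanophenyl group, brings an at least 9.8-fold lower number from compound 1 to compound 3 (0.99 log units; beyond the scatter). This gives the first result in the series that is a number rather than a limit, and it shows that a change of a single atom at this position can move the tolerated concentration beyond the scatter. The true size of the step stays unresolved because the value for compound 1 is only a limit: the limit of > 307000 nM in this assay, at which 1 of the 3 values shown sits.

Going by these compounds, whether bromo or methyl on the same carbon would lower the number as chloro does, or leave it at a limit as fluoro does, remains open. Going by these compounds alone, compound 2 differs from compound 1 in more than one place, so it gives no step that can be read for this position.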